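A few compounds are considered here, and "the series" means these few. Any claim that something is new, unique, unknown or untested is made for them only; others in the source may bear on it.

Measured so far:
compound 1, `N#Cc1ccccc1Oc1ccc([C@H]2CC[C@@H](C(N)=O)N2)cc1` — in an ADME assay on brain (Rattus norvegicus) for protein binding (a lower number here means a smaller unbound share, a higher number a larger unbound share of the compound), compound 1 gives 0.076
compound 2, `NC(=O)[C@@H]1CC[C@H](c2ccc(Oc3ccccc3)cc2)N1` — in this assay compound 2 gives "not determined" (no result reported)

Within the data shown here, compound 1 is the only member of the series with a number in this assay, and its unbound share is small. Among the measured compounds shown here, compound 2 stands without any number in this assay; its result is recorded as "not determined" (no result reported), so no comparison of the two measured compounds is possible and no step between them is known.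

Compound 3, `NC(=O)[C@@H]1CC[C@H](c2ccc(Oc3ccc(F)cc3)cc2)N1`, is the next compound to be run. It differs from compound 2 by fluoro in place of hydrogen on an aromatic carbon. For the measured compounds named here, with no measured step to lean on, the change is expected to move the unbound share in this assay only a little, if anything towards a smaller share, and not beyond the usual scatter.

For compound 3 the unbound fraction in this assay is estimated at 0.055, with a range of 0.02 to 0.13.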

Compound 3, unbound fraction: 0.016
The estimate for compound 3 lay 3.4-fold (0.54 log units) above the measured number; measured number below the stated range.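

In this assay compound 3 gives 0.016 while compound 2 stands at "not determined" (no result reported), so no step can be read between compound 2 and compound 3. The compounds shown leave open what fluoro in place of hydrogen does to the unbound share. No supporting evidence bears on this result.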